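The compounds below may be only part of what the source reports. "The series", "measured", "known", "first", "only" and "open" are said of these compounds alone.

Working notes on the series. In an assay on isolated protein for binding affinity to Equilibrative nucleoside transporter 1 (Homo sapiens) (on this read-out higher numbers stand for weaker inhibition and lower numbers for stronger inhibition), compound 1 `OC[C@H]1O[C@@H](n2cnc3c(NCc4ccco4)ncnc32)[C@H](O)[C@@H]1O` gives 36300 nM. Compound 2 `CCCCSc1nc(N)nc2c1ncn2[C@@H]1O[C@H](CO)[C@@H](O)[C@H]1O` gives 12000 nM in this assay. For the measured compounds named here, of the two numbers so far, compound 2 holds the lower one, and the gap up to compound 1 lies beyond the scatter of repeated measurements. Going by the values given here, these two compounds differ in more than one place, so no single structural step is separated out between them. Compound 3 `CC(C)Sc1nc(N)nc2c1ncn2[C@@H]1O[C@H](CO)[C@@H](O)[C@H]1O` has not yet been measured in this assay. It differs from compound 2 by isopropyl in place of butyl on a sulfur. Among the compounds with values here, no measured pair shows what such a change does; the one gap on hand, that between compound 1 and compound 2, turns on other changes. The step is therefore expected to be small, a 1.3-fold higher number from compound 2 to compound 3 (0.10 log units; within the scatter), not clearly beyond the scatter in either direction. For compound 3 the estimate in this assay is 15000 nM, with a range of 5000 nM to 45000 nM.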

Compound 3, half-maximal inhibitory concentration: 191000 nM
For compound 3 the middle estimate is 13-fold (1.10 log units) below the measured one; the measured number lies above the stated range.
By their numbers in this assay, from the lowest: compound 2; then compound 1; then compound 3.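

In this assay, for the compounds shown here, the first single-place comparison shows that the group on a sulfur whose other neighbour is an aromatic carbon strongly affects the read-out: isopropyl in place of butyl gives a 16-fold higher number from compound 2 to compound 3 (1.20 log units; beyond the scatter) on the otherwise shared core. The earlier compounds shown here could not show this, as they differ in more than one place. The size of the step is notable given how little the counted features change: both groups are carbon-only, with no ring, no hydrogen-bond donors or acceptors and no net charge, and they have 4 and 3 heavy atoms.

A straight propyl chain, a sec-butyl group, a longer chain such as hexyl or a benzyl group on the sulfur would help separate chain length from branching. No measurement on hand explains why this change has such a large effect.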